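Removing one methyl from compound 3

The compounds below may be only part of what the source reports. "The series", "measured", "known", "first", "only" and "open" are said of these compounds alone.

Compound 1 `COc1cccc(/C=C2\CCC/C(=C\c3cccc(OC)c3OC)C2=O)c1`: 7000 nM
Compound 2 `COc1cccc(/C=C2\CCC/C(=C\c3cc(Cl)cc(Cl)c3)C2=O)c1OC`: 5500 nM
Compound 3 `COc1cc(/C=C2\CCC/C(=C\c3cccc(OC)c3OC)C2=O)ccc1O`: 8600 nM

These numbers come from a functional assay on SW-620 cells (Homo sapiens) for cytotoxicity, read by MTT assay, with a stated time of 72 h (on this read-out higher numbers stand for weaker inhibition and lower numbers for stronger inhibition), and sit close together. Compound 3 stands within the scatter of both others, with a 1.2-fold higher number from compound 1 to compound 3 (0.09 log units; within the scatter) and a 1.6-fold higher number from compound 2 to compound 3 (0.19 log units; within the scatter) as its steps. Compound 4 `COc1cccc(/C=C2\CCC/C(=C\c3ccc(O)c(O)c3)C2=O)c1OC` differs from compound 3 by hydrogen in place of methyl on an oxygen on an aromatic ring and so carries hydrogen in place of methyl on an oxygen on an aromatic ring. The closest measured change, hydroxy in place of hydrogen on an aromatic carbon, gave a 1.2-fold higher number from compound 1 to compound 3 (0.09 log units; within the scatter) and stayed within the scatter. Exchanging a whole aryl group gave only a 1.3-fold lower number from compound 1 to compound 2 (0.10 log units; within the scatter) as well. The estimated change is therefore small, with a 1.4-fold lower number from compound 3 to compound 4 (0.16 log units; within the scatter) expected and nothing beyond the scatter. In this assay compound 4 is expected near 6000 nM with an estimated range from 2500 nM to 13000 nM as its likely span.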

Compound 4, half-maximal inhibitory concentration: 6300 nM
Beside the measured number, compound 4's estimate is 1.1-fold (0.02 log units) below it; the range from low to high includes it.
By their numbers in this assay, from the lowest: compounds 2, 4, 1 and 3 (each within the scatter of the next).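

In this assay, methoxy to hydroxy on the aromatic ring gave a 1.4-fold lower number from compound 3 to compound 4 (0.14 log units; within the scatter), so freeing this oxygen produced no readable change. The 3,4-dihydroxyphenyl group also stayed level with the other aryl groups, with a 1.1-fold higher number from compound 2 to compound 4 (0.06 log units; within the scatter) and a 1.1-fold lower number from compound 1 to compound 4 (0.05 log units; within the scatter). Nothing available explains why these numbers remain so close. Going by these compounds, whether an amine in place of the hydroxy, or a longer chain on the oxygen, would move the number beyond the scatter remains open.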